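Pyridyl for phenyl on the indazole core: cytotoxicity notes

The source may report more compounds than this note shows. Statements on the series, on what has been measured and on what is new or still open speak of the compounds shown alone.

Compound 1 `O=C([C@H]1CCN1S(=O)(=O)c1c(F)c(F)c(F)c(F)c1F)N(Cc1ccc(C2CCCCC2)cc1)c1ccc2c(=O)[nH]ccc2c1` is the reference; in an ADME assay on MCF-10A cells (Homo sapiens) for cytotoxicity, with a stated time of 72 h (on this read-out lower numbers stand for an effect already at smaller amounts and higher numbers for an effect only at larger amounts of compound), compound 1 gives 5300 nM. Compound 2 `O=C([C@H]1CCN1S(=O)(=O)c1c(F)c(F)c(F)c(F)c1F)N(Cc1ccc(C2CCCCC2)cn1)c1ccc2c(=O)[nH]ccc2c1` differs from it by 5-cyclohexylpyridin-2-yl in place of 4-cyclohexylphenyl on a saturated chain carbon bound to an amide-type nitrogen and in this assay compound 2 gives 2700 nM, so that a 2.0-fold lower number from compound 1 to compound 2 (0.29 log units; within the scatter). Compound 3 `O=C([C@H]1CCN1S(=O)(=O)c1c(F)c(F)c(F)c(F)c1F)N(Cc1ccc(C2CCCCC2)cc1)c1cc2[nH]ncc2cc1F` keeps the 4-cyclohexylphenyl group of compound 1 but has a different core: a group of 10 heavy atoms (7 carbon, 2 nitrogen, 1 fluorine; one five-membered aromatic ring with 2 hetero atoms, one six-membered aromatic ring of carbon only) in place of a group of 11 heavy atoms (9 carbon, 1 nitrogen, 1 oxygen; one six-membered aromatic ring of carbon only, one six-membered aromatic ring with 1 hetero atom), on an amide-type nitrogen. In this assay compound 3 gives 8100 nM; the step is a 1.5-fold higher number from compound 1 to compound 3 (0.18 log units; within the scatter). Compound 2 and compound 3 differ by a gap beyond the scatter, compound 3 standing at the higher number.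

Compound 4 `O=C([C@H]1CCN1S(=O)(=O)c1c(F)c(F)c(F)c(F)c1F)N(Cc1ccc(C2CCCCC2)cn1)c1cc2[nH]ncc2cc1F` is not yet measured. It is obtained from compound 3 by 5-cyclohexylpyridin-2-yl in place of 4-cyclohexylphenyl on a saturated chain carbon bound to an amide-type nitrogen, the same change as from compound 1 to compound 2, made at the same place. The expectation for compound 4 rests on that single earlier instance, whose step stayed within the scatter, and on compound 3 standing at 8100 nM. Similar in size and direction to a 2.0-fold lower number from compound 1 to compound 2 (0.29 log units; within the scatter), the step from compound 3 to compound 4 in this assay is expected to be a 1.9-fold lower number from compound 3 to compound 4 (0.28 log units; within the scatter). Compound 4 in this assay is therefore expected near 4300 nM, within a range from 2000 nM to 9500 nM.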

Compound 4, half-maximal effective concentration: 4900 nM
For compound 4 the middle estimate is 1.1-fold (0.06 log units) below the measured one; the measured number falls inside the stated range.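

In this assay, 5-cyclohexylpyridin-2-yl in place of 4-cyclohexylphenyl gives a 1.7-fold lower number from compound 3 to compound 4 (0.22 log units; within the scatter), and the change reads alike on both cores: the same change on two cores in this assay, a 2.0-fold lower number (0.29 log units; within the scatter) from compound 1 to compound 2 and a 1.7-fold lower number (0.22 log units; within the scatter) from compound 3 to compound 4, 1.2-fold (0.07 log units) apart, within the scatter of two such steps. The core exchange, read on the pyridine-bearing pair, gives a 1.8-fold higher number from compound 2 to compound 4 (0.26 log units; within the scatter), and it too reads alike in the two settings: the same change on two cores in this assay, a 1.5-fold higher number (0.18 log units; within the scatter) from compound 1 to compound 3 and a 1.8-fold higher number (0.26 log units; within the scatter) from compound 2 to compound 4, 1.2-fold (0.07 log units) apart, within the scatter of two such steps. For the compounds shown here, since each of these steps stays within the scatter, the four compounds show only that both changes carry over as small steps that agree, not that either change has a real effect on this read-out, and the agreement rests on just two cores and one pair of aromatic rings.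

Still open, as far as these compounds go, is how the pyridine exchange behaves on any third core. Also open, from the compounds shown here alone, is whether the steps stay this small when an amine or a carboxylic acid stands in place of the cyclohexyl group.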